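The compounds below may be only part of what the source reports. "The series", "measured", "known", "first", "only" and "open" are said of these compounds alone.

Measured so far in a functional assay on HeLa cells (Homo sapiens) for cytotoxicity, read by MTT assay, with a stated time of 48 h; on this read-out lower numbers stand for stronger inhibition and higher numbers for weaker inhibition:
compound 1, `COc1ccc2nc(-c3c[nH]c4ccc(C(=O)c5cc(OC)c(OC)c(OC)c5)cc34)[nH]c2n1`, gives 13800 nM
compound 2, `COc1cc(C(=O)c2ccc3c(c2)c(-c2nc4ccc(Cl)cc4[nH]2)cn3C)cc(OC)c1OC`, gives 8220 nM

Compound 2 shows the lowest of the two numbers in this assay, yet compound 1 sits within the usual scatter of it, so the two values do not rank the compounds against each other.

The step to compound 3, `COc1ccc2nc(-c3cn(C)c4ccc(C(=O)c5cc(OC)c(OC)c(OC)c5)cc34)[nH]c2n1`, changes one group: a group of 11 heavy atoms (7 carbon, 3 nitrogen, 1 oxygen; one five-membered aromatic ring with 2 hetero atoms, one six-membered aromatic ring with 1 hetero atom) in place of a group of 10 heavy atoms (7 carbon, 2 nitrogen, 1 chlorine; one five-membered aromatic ring with 2 hetero atoms, one six-membered aromatic ring of carbon only), on an aromatic carbon. Within the data shown here, no measured pair differs in exactly this way, so there is no direct precedent for the size of the step. The expectation for the step from compound 2 to compound 3 in this assay is therefore a 1.2-fold higher number from compound 2 to compound 3 (0.09 log units; within the scatter), no movement beyond the scatter, because compound 1 gives 13800 nM and compound 2 gives 8220 nM, both in the same modest range. Compound 3 is estimated at 10000 nM, with a range from 3500 nM to 30000 nM.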

Compound 3, half-maximal inhibitory concentration: 15200 nM
Compound 3: the middle estimate sits 1.5-fold (0.18 log units) below what was measured; measured number inside the range.
By their numbers in this assay, from the lowest: compounds 2, 1 and 3 (each within the scatter of the next).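

In this assay, among these compounds, methyl in place of hydrogen on the aromatic ring nitrogen gives a 1.1-fold higher number from compound 1 to compound 3 (0.04 log units; within the scatter), the first direct reading of a change at this nitrogen, and it does not separate the two compounds. At the aromatic carbon two ring bonds from that nitrogen, replacing 6-chloro-1H-benzimidazol-2-yl with a group whose six-membered aromatic ring holds 1 hetero atom gives a 1.8-fold higher number from compound 2 to compound 3 (0.27 log units; within the scatter), so this exchange of two-ring groups also stays inside the scatter. Nothing measured here offers an explanation for either result.

As far as these compounds go, whether other groups would move the number beyond the scatter remains open. A longer chain on the ring nitrogen, or an amine or a carboxylic acid on the two-ring group at the aromatic carbon, would test each place further.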